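Chloropurine glycinamide series: side-chain carboxy to isopropyl

This account rests on a few compounds, and the source may have more. Where it says the series, first, only, none or still open, it means among the compounds named here.

Measured compounds in a functional assay on the whole organism (Tail, strain ICR) with Mus musculus as the target, in the tail flick test, with a stated time of 90 min, at a dose of 25 umol/kg by the oral route; a higher number here means a stronger effect of the compound at the dose given, a lower number a weaker effect:
- Compound 1, `NC(=O)CC[C@H](NC(=O)CN(c1ncnc2c1ncn2C1CCCCO1)C1CC1)C(=O)OCc1ccccc1`: compound 1 gives 37.8%
- Compound 2, `O=C(O)C[C@H](NC(=O)CN(c1nc(Cl)nc2[nH]cnc12)C1CC1)C(=O)O`: compound 2 gives 25.1%
- Compound 3, `NC(=O)C[C@H](NC(=O)CN(c1nc(Cl)nc2[nH]cnc12)C1CC1)C(=O)OCc1ccccc1`: compound 3 gives 32.3%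

Compound 2 carries the lowest of the three numbers. Its distance to compound 3 lies within the usual scatter, so no order between those two can be read; its distance to compound 1 lies beyond the scatter, so compound 2 does stand below compound 1 in this assay.

Compound 4, `CC(C)C[C@H](NC(=O)CN(c1nc(Cl)nc2[nH]cnc12)C1CC1)C(=O)O`, is not yet measured. It differs from compound 2 in one place: isopropyl in place of carboxy on a saturated chain carbon, two bonds along the chain from an amide-type nitrogen and a carbonyl carbon. Going by the values given here, no step between two measured compounds covers this change, and the three measured values spread only across a narrow band, so there is no basis to expect a step beyond the scatter in either direction.

Compound 4 is expected near 30% in this assay, with a range from 10% to 52%. The expected step of a number 4.9 percentage points higher from compound 2 to compound 4 (within the scatter) is therefore estimated to fall within the scatter of this kind of measurement.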

Compound 4, a percentage reported as activity, at one dose (the size of the read-out at that dose, not a potency): 27%
Beside the measured number, compound 4's estimate is 3 percentage points above it; measured number inside the range.
By their numbers in this assay, from the lowest: compounds 2, 4, 3 and 1 (each within the scatter of the next, the first and the last beyond it).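

In this assay, isopropyl in place of carboxy on a saturated chain carbon, two bonds along the chain from an amide-type nitrogen and a carbonyl carbon, gives a number 1.9 percentage points higher from compound 2 to compound 4 (within the scatter). Carboxy at this place is therefore not required for the effect seen at this one dose: a group counted with no hydrogen-bond donor or acceptor reads the same within the scatter, though a single-dose read-out says nothing about potency. Nothing available here bears on why the two groups read alike.

Going by these compounds, it remains open whether an amine, a phenyl ring or a longer chain at this place would separate from carboxy and isopropyl beyond the scatter. On these data alone, the same exchange also remains untested at other doses, times and routes.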